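A few compounds are considered here, and "the series" means these few. Any claim that something is new, unique, unknown or untested is made for them only; others in the source may bear on it.

Compound 1, `CC(Cl)CC(=O)NC1=C(C#N)C(c2ccc(Cl)cc2Cl)C2=C(CCCC2=O)N1c1ccc(S(N)(=O)=O)cc1`, gives 50% in a functional assay on Ehrlich cells (Mus musculus) for cytotoxicity, read by trypan blue exclusion, with a stated time of 2 h, tested at 25 ug/mL; on this read-out higher numbers stand for a stronger effect at the one concentration tested and lower numbers for a weaker effect.
Compound 2, `N#CC1=C(NC(=O)c2ccc([N+](=O)[O-])cc2)N(c2ccc(S(N)(=O)=O)cc2)C2=C(C(=O)CCC2)C1c1ccc(Cl)cc1Cl`, gives 40% in this assay.

For the measured compounds named here, of the two numbers measured, the one for compound 2 is the smaller, yet the step of a number 10 percentage points lower from compound 1 to compound 2 (within the scatter) lies within the usual scatter, so the two compounds cannot be told apart on this read-out. That step exchanged one group on the carbonyl carbon for another and left the cytotoxicity essentially unchanged.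

Compound 3, `COc1cc(C(=O)NC2=C(C#N)C(c3ccc(Cl)cc3Cl)C3=C(CCCC3=O)N2c2ccc(S(N)(=O)=O)cc2)cc(OC)c1OC`, is built on the same shared core and differs from compound 2 at the same position: 3,4,5-trimethoxyphenyl in place of 4-nitrophenyl on a carbonyl carbon. Going by the values given here, the only measured step that bears on this place is a number 10 percentage points lower from compound 1 to compound 2 (within the scatter), and it stayed within the scatter. There is therefore no basis for expecting a shift beyond the scatter, and the step is estimated as a number 2 percentage points higher from compound 2 to compound 3 (within the scatter). Compound 3 is expected to give about 42%, with a range from 25% to 60%.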

Compound 3, a percentage reported as activity, at one concentration (the size of the read-out at that concentration, not a potency): 20%
Beside the measured number, compound 3's estimate is 22 percentage points above it; the measured number lies below the stated range.
By their numbers in this assay, from the lowest: compound 3; then compounds 2 and 1 (each within the scatter of the next).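

The group on the carbonyl carbon can make a real difference in this assay: 3,4,5-trimethoxyphenyl in place of 4-nitrophenyl gives a number 20 percentage points lower from compound 2 to compound 3 (beyond the scatter), and 3,4,5-trimethoxyphenyl in place of 2-chloropropyl gives a number 30 percentage points lower from compound 1 to compound 3 (beyond the scatter). The position is therefore not indifferent, as the first pair alone might have suggested, and compound 3, with the 3,4,5-trimethoxyphenyl group, is the weakest of the three at the one concentration tested. Nothing available here explains why this group goes with the weaker effect. The compounds shown leave open how an amine or a carboxylic acid on the carbonyl carbon would read. They also leave open whether a phenyl ring carrying a single methoxy group would behave like 3,4,5-trimethoxyphenyl or like 4-nitrophenyl.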